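A Methoxy for a Fluoro in Compound 4

The compounds below may be only part of what the source reports. "The series", "measured", "known", "first", "only" and "open" are said of these compounds alone.

Of the compounds shown here, three with a shared core have been measured in an ADME assay on WI-38 cells (Homo sapiens) for cytotoxicity, read by MTT assay, with a stated time of 72 h; on this read-out lower numbers stand for stronger inhibition and higher numbers for weaker inhibition. Compound 1 `O=C(CCc1cccc2c1B(O)OC2)Nc1cccc(I)c1` gives 71000 nM. Compound 2 `C#Cc1cccc(NC(=O)CCc2cccc3c2B(O)OC3)c1` reads > 100000 nM, which is a limit of the assay and not a number. Compound 3 `O=C(CCc1cccc2c1B(O)OC2)Nc1cccc(-c2ccc(F)cc2)c1` gives 4100 nM, the lowest of the two actual numbers. Compound 4 `COc1ccc(-c2cccc(NC(=O)CCc3cccc4c3B(O)OC4)c2)cc1` differs from compound 3 in one place: methoxy in place of fluoro on an aromatic carbon. Methoxy stands in place of fluoro on an aromatic carbon, para to a large group, turning 4-fluorophenyl into 4-methoxyphenyl.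

Going by the values given here, no measured step makes this exact change. The nearest evidence is a 17-fold lower number from compound 1 to compound 3 (1.24 log units; beyond the scatter) and an at least 24-fold lower number from compound 2 to compound 3 (1.38 log units; beyond the scatter), both large, and each brings in the 4-fluorophenyl group. By contrast, an at least 1.4-fold higher number from compound 1 to compound 2 (0.14 log units; that floor lies within the scatter) stays within the scatter. Compound 4 keeps the phenyl group and changes only its outer substituent, so the expectation stays anchored to compound 3 at 4100 nM. The expected step is a 1.1-fold higher number from compound 3 to compound 4 (0.04 log units; within the scatter), which would not go beyond the scatter. For compound 4 the estimated value is 4500 nM, with an expected range of 1500 nM to 14000 nM.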

Compound 4, half-maximal inhibitory concentration: 1400 nM
Beside the measured number, compound 4's estimate is 3.2-fold (0.51 log units) above it, and the stated range ends above it.
By their numbers in this assay, from the lowest: compound 4; then compound 3; then compound 1. At a limit, above all of these: compound 2.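

In this assay, going by these compounds alone, the earlier compounds showed only that bringing in a 4-fluorophenyl group lowers the number, whereas this result shows that the outer substituent, para to a large group, also counts: a 2.9-fold lower number from compound 3 to compound 4 (0.47 log units; beyond the scatter), a modest step but one beyond the scatter. With 4-methoxyphenyl in place of iodo, the large drop seen with 4-fluorophenyl grows further, to a 51-fold lower number from compound 1 to compound 4 (1.71 log units; beyond the scatter). The other large step, an at least 71-fold lower number from compound 2 to compound 4 (1.85 log units; beyond the scatter), starts from a limit of the assay and not a number, so it is only a floor: the limit of > 100000 nM in this assay, at which 1 of the 4 values shown sits.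

Fluoro and methoxy are the only two substituents shown at this place, so they establish no trend. The compounds leave open whether an amine, a hydroxyl or an ethoxy there would read lower or higher than compound 4.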